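Swapping the amide substituent for a pyridinylmethyl group

The compounds below may be only part of what the source reports. "The series", "measured", "known", "first", "only" and "open" are said of these compounds alone.

Measured so far:
compound 1 `COc1cc(-c2cc(C(=O)O)c3ccccc3n2)ccc1OCC(=O)Nc1ccc(C)cc1` 1.2
compound 2 `COc1cc(-c2cc(C(=O)O)c3ccccc3n2)ccc1OCC(=O)Nc1cccc(Cl)c1` 2.3

In a physicochemical assay for lipophilicity, using the shake flask method, in phosphate buffer, measured as octanol-water partition, at pH 7.4 (a lower number here means a more polar compound, a higher number a more lipophilic compound), compound 2 stands highest of the two numbers, with compound 1 lying a number 1.10 log units higher from compound 1 to compound 2 (beyond the scatter). Compound 3 `COc1cc(-c2cc(C(=O)O)c3ccccc3n2)ccc1OCC(=O)NCc1cccnc1` carries the change ((pyridin-3-yl)methyl in place of 3-chlorophenyl on an amide-type nitrogen). That single measured step shows that exchanging the group on the amide nitrogen can move this assay by a large amount. The group entering here brings a ring with one hetero atom and one hydrogen-bond acceptor, so a large drop is expected. Compound 3 is estimated at 0.6, between 0 and 1.2, an expected step of a number 1.70 log units lower from compound 2 to compound 3 (beyond the scatter).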

Compound 3, distribution coefficient: -0.8
Compound 3: the middle estimate sits 1.40 log units above what was measured, and the stated range ends above it.
By their numbers in this assay, from the lowest: compound 3; then compound 1; then compound 2.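

In this assay, placing (pyridin-3-yl)methyl on the amide-type nitrogen gives a number 3.10 log units lower from compound 2 to compound 3 (beyond the scatter) and a number 2.00 log units lower from compound 1 to compound 3 (beyond the scatter) in the same sentence of change. The earlier compounds shown here showed only the rise between 4-methylphenyl and 3-chlorophenyl, whereas this place can also take the number well under both. No measurement here explains the fall.

The new group differs in both its ring nitrogen and its methyl link, and the compounds shown do not separate the two. A phenylmethyl group, or pyridin-3-yl directly on the amide nitrogen, would tell them apart.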